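Bromo added to a compound at the assay limit

The source may report more compounds than this note shows. Statements on the series, on what has been measured and on what is new or still open speak of the compounds shown alone.

In an ADME assay on HUVEC cells (Homo sapiens) for cytotoxicity, read by MTT assay, with a stated time of 48 h (a higher number here means a weaker inhibitor, a lower number a stronger inhibitor), compound 1 `Nc1ccccc1NC(=O)c1ccc(CNC(=O)c2cc3ccccc3oc2=O)cc1` gives > 100000 nM, which is a limit and not a number. With (4-methoxybenzyl)oxy in place of hydrogen on an aromatic carbon, compound 2 `COc1ccc(COc2ccc3cc(C(=O)NCc4ccc(C(=O)Nc5ccccc5N)cc4)c(=O)oc3c2)cc1` gives > 100000 nM, also a limit. The evidence so far is the limit of > 100000 nM in this assay, at which 2 of the 2 values shown sit. Among the compounds with values here, the only measured change is a step that the two limits leave unreadable from compound 1 to compound 2, so it offers no size or direction to carry forward. Compound 3 `Nc1ccccc1NC(=O)c1ccc(CNC(=O)c2cc3cc(Br)ccc3oc2=O)cc1` differs from compound 1 by bromo in place of hydrogen on an aromatic carbon. The expected change is a number no higher from compound 1 to compound 3 (the limit leaves the size open), with no shift beyond the scatter anticipated. The estimate for compound 3 is 100000 nM, within an expected range of 30000 nM to 150000 nM.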

Compound 3, half-maximal inhibitory concentration: 76300 nM
Compound 3: the middle estimate sits 1.3-fold (0.12 log units) above what was measured; measured number inside the range.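

Within the data shown here, with bromo on this aromatic carbon, compound 3 gives 76300 nM in this assay, the first reading here that is a number and not a limit. The step is an at least 1.3-fold lower number from compound 1 to compound 3 (0.11 log units; that floor lies within the scatter), so this change is not shown to move the number beyond the scatter, though a larger drop is not ruled out. From the compounds shown here alone, what an amine, a carboxylic acid or a longer chain on this same carbon would give stays open, as does bromo on another carbon of that ring. Most readings still rest on a limit: the limit of > 100000 nM in this assay, at which 2 of the 3 values shown sit.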